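This account rests on a few compounds, and the source may have more. Where it says the series, first, only, none or still open, it means among the compounds named here.

Measured so far:
Compound 1 `N=C(N)c1cccc(CN2CC[C@H](NS(=O)(=O)c3ccc(-c4ccccn4)cc3)C2=O)c1` – in an assay on isolated protein for inhibition of Trypsin II (Bos taurus) (a lower number here means a stronger inhibitor, a higher number a weaker inhibitor), compound 1 gives > 2900 nM, a limit of the assay only.
Compound 2 `C[n+]1ccc(-c2ccc(S(=O)(=O)N[C@H]3CCN(Cc4cccc(C(=N)N)c4)C3=O)cc2)cc1` – in this assay compound 2 gives > 2900 nM, again a limit of the assay.

Compound 1 thus stands at the limit, with no number of its own; (the limit of > 2900 nM in this assay, at which 2 of the 2 values shown sit). The change to compound 3 `Cn1ccnc1-c1ccc(S(=O)(=O)N[C@H]2CCN(Cc3cccc(C(=N)N)c3)C2=O)cc1` is 1-methyl-1H-imidazol-2-yl in place of pyridin-2-yl on an aromatic carbon. Among the compounds with values here, the only measured step, a step that the two limits leave unreadable from compound 1 to compound 2, concerns another exchange on an aromatic carbon, but its size cannot be read. No direction beyond the scatter can be anticipated. Compound 3 is expected to stay near the limit, estimated at 6000 nM (range 2000 nM to 25000 nM). The expected step is a step that the limit leaves unreadable from compound 1 to compound 3.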

Compound 3, inhibition constant: > 2900 nM
Compound 3: a limit, no number (the forecaster's own chance of this, stated with the estimate: 80%); the middle value is on the limit's open side.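

Within the data shown here, no step among compound 1, compound 2 and compound 3 can be read in this assay: the limit of > 2900 nM in this assay, at which 3 of the 3 values shown sit. Going by these compounds, how pyridin-2-yl and 1-methyl-1H-imidazol-2-yl compare in this assay remains open, with no number for compound 1 or compound 3.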